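The compounds below may be only part of what the source reports. "The series", "measured", "known", "first", "only" and "open" are said of these compounds alone.

In a functional assay on cells (Homo sapiens) for antiproliferative activity, read by WST assay, with a stated time of 3 days (a lower number here means a stronger inhibitor, a higher number a weaker inhibitor), compound 1 `O=c1cc(I)n([C@@H]2O[C@H](CO)[C@@H](O)[C@H]2O)c(=O)[nH]1` gives 27800 nM. Compound 2 `O=c1[nH]c(=O)n([C@@H]2O[C@H](CO)[C@@H](O)[C@H]2O)c(I)c1F` is reported only as a limit of the assay, > 50000 nM. Compound 3 `O=Cc1c(F)c(=O)[nH]c(=O)n1[C@@H]1O[C@H](CO)[C@@H](O)[C@H]1O` gives 400 nM. Going by these compounds, compound 2 therefore has no exact number, and its distance from compound 1 stays open. Compound 4 `O=c1[nH]c(=O)n([C@@H]2O[C@H](CO)[C@@H](O)[C@H]2O)c(I)c1Br` carries bromo in place of fluoro on an aromatic carbon, ortho to an iodo group: bromo in place of fluoro on an aromatic carbon. Going by the values given here, two measured steps bear on this. Fluoro in place of hydrogen gave an at least 1.7-fold higher number from compound 1 to compound 2 (0.25 log units; that floor lies within the scatter), with a floor inside the scatter. The large change, an at least 120-fold lower number from compound 2 to compound 3 (2.09 log units; beyond the scatter), came with formyl in place of iodo, and compound 4 keeps the iodo group. No step beyond the scatter is therefore expected in this assay. The estimate for compound 4 is 40000 nM, with an expected range from 15000 nM to 100000 nM. That would be an expected at least 1.2-fold lower number from compound 2 to compound 4 (0.09 log units; that floor lies within the scatter).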

Compound 4, half-maximal inhibitory concentration: > 50000 nM
Compound 4 gave a limit, no number; the forecaster's own chance of this, stated with the estimate: 50%; middle value at least 1.2-fold (0.09 log units) away from the limit.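

In this assay, compound 4, like compound 2, is reported only as a limit, so the step between them cannot be read and bromo and fluoro cannot be ranked at this position. Bromo in place of hydrogen gave an at least 1.7-fold higher number from compound 1 to compound 4 (0.25 log units; that floor lies within the scatter), so a second halogen here also shows only a floor. Both compounds therefore stop at the same limit: the limit of > 50000 nM in this assay, at which 2 of the 4 values shown sit.

Going by these compounds, whether a small group such as an amine or a methyl at this position, with the iodo group kept, would give a readable number remains open. So does whether formyl in place of iodo would work with bromo as it does in compound 3, at 400 nM.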